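This account rests on a few compounds, and the source may have more. Where it says the series, first, only, none or still open, it means among the compounds named here.

Going by the values given here, compound 2 `CC[C@H](C)[C@@H]1C(=O)N[C@H](C2Cc3ccccc3C2)C(=O)N1[C@@H](C(=O)N(C)C)c1cnc(C)cc1C` holds the lowest number of the two compounds so far measured in an assay on isolated protein for displacement of a labelled ligand from Oxytocin receptor (Homo sapiens); on this read-out higher numbers stand for weaker inhibition and lower numbers for stronger inhibition; in this assay compound 2 gives 0.0398 nM. Among the compounds with values here, its only neighbour is compound 1 `CC[C@H](C)[C@@H]1C(=O)N[C@H](C2Cc3ccccc3C2)C(=O)N1[C@@H](C(=O)N(C)C)c1ccc(C)[n+]([O-])c1`, which in this assay gives 1 nM. Within the data shown here, the single measured step, a 25-fold lower number from compound 1 to compound 2 (1.40 log units; beyond the scatter), was a large one, and it concerned the aromatic ring carried on the saturated chain carbon bound to the amide-type nitrogen in the ring and a carbonyl carbon.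

Compound 3 `CC[C@H](C)[C@@H]1C(=O)N[C@H](C2Cc3ccccc3C2)C(=O)N1[C@@H](C(=O)NC)c1cnc(C)cc1C` differs from compound 2 at another place: hydrogen in place of methyl on an amide-type nitrogen, which, read one bond further out, is dimethylcarbamoyl to methylcarbamoyl. Among the measured compounds shown here, no measured step touches this amide-type nitrogen; the step from compound 1 to compound 2 changed a different part of the structure and offers no direct guide. For the measured compounds named here, with nothing among the measured compounds pointing either way, compound 3 is expected to remain close to compound 2, the step of a 2.0-fold higher number from compound 2 to compound 3 (0.30 log units; within the scatter) being modest and possibly not beyond the scatter. The estimate for compound 3 in this assay is therefore 0.08 nM, within a range of 0.015 nM to 0.5 nM.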

Compound 3, inhibition constant: 0.0631 nM
The estimate for compound 3 lay 1.3-fold (0.10 log units) above the measured number, and the stated range covers the measured number.
By their numbers in this assay, from the lowest: compounds 2 and 3 (each within the scatter of the next); then compound 1.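

Going by these compounds alone, replacing methyl with hydrogen on the amide-type nitrogen gave a 1.6-fold higher number from compound 2 to compound 3 (0.20 log units; within the scatter) in this assay, the first measured change at this position, and it shows that dimethylcarbamoyl and methylcarbamoyl cannot be separated on this read-out. Set against a 25-fold lower number from compound 1 to compound 2 (1.40 log units; beyond the scatter), which concerned the aromatic ring, the step at this nitrogen is small, so among these three compounds the ring change is the only one that moves the number beyond the scatter. No accompanying measurement bears on this result, and the numbers alone give no account of it.

What the compounds shown leave open is whether this nitrogen would stay as undemanding with the remaining methyl also replaced by hydrogen, giving the primary amide, or with a larger substituent such as ethyl or cyclopropyl. Within the data shown here, it also remains open whether the change from methyl to hydrogen would read the same way with the aromatic ring of compound 1, since the only pair that shows this change carries the ring of compound 2.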